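The compounds below may be only part of what the source reports. "The series", "measured", "known", "first", "only" and "open" are said of these compounds alone.

Compound 1 `BrCCCCc1ccc(-c2ccc(-c3ccc(CCCCBr)s3)s2)s1`: > 200000 nM
Compound 2 `O=C(NCCCc1ccc(-c2ccc(-c3cccs3)s2)s1)c1cc(F)cc(C(F)(F)F)c1`: "not determined" (no result reported)
Compound 3 `O=C(NCCCCc1ccc(-c2ccc(-c3cccs3)s2)s1)c1cc(F)cc(C(F)(F)F)c1`: "not determined" (no result reported)

In an ADME assay on MDCK cells (Canis lupus familiaris) for cytotoxicity, read by MTT assay, with a stated time of 2 days (on this read-out lower numbers stand for higher toxicity in this test and higher numbers for lower toxicity in this test), compound 1 reads > 200000 nM, which is a limit of the assay and not a number. Going by the values given here, compound 2 and compound 3 add no number, so no measured compound in this set has an exact reading. Compound 4 `BrCCCCc1ccc(-c2ccc(-c3cccs3)s2)s1` shares the core of compound 1 and differs from it in one place: hydrogen in place of 4-bromobutyl on an aromatic carbon. This puts hydrogen in place of 4-bromobutyl on an aromatic carbon, next to the ring sulfur.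

Among the compounds with values here, no measured pair shows what such a change does in this assay, and the only guide is compound 1, whose limit is the limit of > 200000 nM in this assay, at which 1 of the 3 values shown sits. A small move toward lower numbers is expected, possibly none beyond the scatter, and a second limit reading would fit this expectation. The estimated step is an at least 1.3-fold lower number from compound 1 to compound 4 (0.12 log units; that floor lies within the scatter). For compound 4, the expected value is 150000 nM, within an estimated range of 50000 nM to 300000 nM.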

Compound 4, half-maximal cytotoxic concentration: 23800 nM
Beside the measured number, compound 4's estimate is 6.3-fold (0.80 log units) above it; the measured number lies below the stated range.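

In this assay, hydrogen in place of 4-bromobutyl on an aromatic carbon, next to the ring sulfur, gives an at least 8.4-fold lower number from compound 1 to compound 4 (0.92 log units; beyond the scatter). Going by these compounds alone, this is the first sign that this place matters in the test, as removing the chain shifts the reading beyond the scatter and compound 4 gives the only exact number in the set. Compound 1 reads as a limit and not a number, so the step gives only a floor for the change: the limit of > 200000 nM in this assay, at which 1 of the 4 values shown sits.

The steps to compound 2 and compound 3 cannot be read, so the amide side chains add nothing to this comparison. From the compounds shown here alone, it also remains open whether a plain butyl chain, a shorter bromoalkyl chain or an amine in place of 4-bromobutyl would read closer to compound 1 or to compound 4.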